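The source may report more compounds than this note shows. Statements on the series, on what has been measured and on what is new or still open speak of the compounds shown alone.

Three compounds share one core and differ only in the group attached to a carbonyl carbon on the amide-type nitrogen in a ring. Compound 1 `CCC(=O)N1CCCn2nc(COc3ccccc3)cc21` carries an ethyl there, compound 2 `O=C(C1CCC1)N1CCCn2nc(COc3ccccc3)cc21` a cyclobutyl, and compound 3 `O=C(c1cccc(F)c1)N1CCCn2nc(COc3ccccc3)cc21` a 3-fluorophenyl. In a functional assay on HEK293 cells for positive allosteric modulation of metabotropic glutamate receptor 5 (Homo sapiens), read by calcium flux (a lower number here means a smaller maximal response, a higher number a larger maximal response), compound 1 gives 48%, compound 2 gives 41%, and compound 3 gives 61%. The step of a number 7 percentage points lower from compound 1 to compound 2 (within the scatter) stays within the scatter, while a number 13 percentage points higher from compound 1 to compound 3 (beyond the scatter) and a number 20 percentage points higher from compound 2 to compound 3 (beyond the scatter) both lie beyond it. Compound 3 thus stands highest of the three, a modest margin above compound 1 and a somewhat larger one above compound 2.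

Compound 4 `O=C(c1ccccn1)N1CCCn2nc(COc3ccccc3)cc21` keeps the core and the carbonyl but changes the aromatic group: pyridin-2-yl in place of 3-fluorophenyl on a carbonyl carbon

Among the compounds with values here, no measured step swaps one six-membered aromatic ring for another, so none bears directly on this change. Within the data shown here, the only steps recorded concern aryl against alkyl groups, and those were modest. With one aromatic ring replaced by another of nearly the same size, the expectation in this assay is a step no larger than the scatter, perhaps slightly downward. For compound 4 the estimated value is 55%, with a range from 40% to 70%, which means an expected step of a number 6 percentage points lower from compound 3 to compound 4 (within the scatter).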

Compound 4, largest response reached (reported as percent of maximum), in percent of the reference or control that the assay uses: 44%
Beside the measured number, compound 4's estimate is 11 percentage points above it; measured number inside the range.
By their numbers in this assay, from the lowest: compounds 2, 4 and 1 (each within the scatter of the next); then compound 3.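

In this assay, this place on a carbonyl carbon proves sensitive to a swap of one aromatic ring for another, with a number 17 percentage points lower from compound 3 to compound 4 (beyond the scatter), so such a swap is not a neutral change here. Compound 4 also sits with the two alkyl compounds, through a number 3 percentage points higher from compound 2 to compound 4 (within the scatter) and a number 4 percentage points lower from compound 1 to compound 4 (within the scatter), so a six-membered aromatic ring at this place does not by itself bring the larger response of compound 3, and compound 4 goes against any simple rule of aromatic over alkyl groups. Nothing available explains why the maximal response drops with this change.

Going by these compounds, the step from compound 3 to compound 4 alters two things at once, since the fluorine leaves and a ring nitrogen with a hydrogen-bond acceptor enters, so the share of each in the drop remains unknown. A plain phenyl group would help to separate the two, and pyridin-3-yl or pyridin-4-yl would show whether the place of the ring nitrogen matters.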